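Working notes: from compound 1 to compound 4

A few compounds are considered here, and "the series" means these few. Any claim that something is new, unique, unknown or untested is made for them only; others in the source may bear on it.

Measured so far in a functional assay on HepG2 cells (Homo sapiens) for cytotoxicity, read by MTT assay, with a stated time of 72 h (a higher number here means a weaker inhibitor, a lower number a stronger inhibitor), for each compound:
- compound 1 `O=C(N/N=C/c1cccc(Cl)c1Cl)Nc1cc2c(Nc3ccc(F)c(Cl)c3)ncnc2cc1O[C@H]1CCOC1` gives 16900 nM
- compound 2 `O=C(N/N=C/c1cc(Br)c(O)c(Br)c1)Nc1cc2c(Nc3ccc(F)c(Cl)c3)ncnc2cc1O[C@H]1CCOC1` gives 2740 nM
- compound 3 `O=C(N/N=C/c1ccc(O)cc1O)Nc1cc2c(Nc3ccc(F)c(Cl)c3)ncnc2cc1O[C@H]1CCOC1` gives 4530 nM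

Compound 1 holds the highest of the three numbers and is the weakest inhibitor of the set, as both steps away from it lie beyond the scatter. Compound 4 `CCN(CC)c1ccc(/C=N/NC(=O)Nc2cc3c(Nc4ccc(F)c(Cl)c4)ncnc3cc2O[C@H]2CCOC2)c(O)c1` has not been measured yet. It keeps the core of compound 1 and carries 4-(diethylamino)-2-hydroxyphenyl in place of 2,3-dichlorophenyl on a carbon with a double bond to nitrogen.

Two measured steps also replace the 2,3-dichlorophenyl. With 3,5-dibromo-4-hydroxyphenyl entering there is a 6.2-fold lower number from compound 1 to compound 2 (0.79 log units; beyond the scatter) and with 2,4-dihydroxyphenyl entering there is a 3.7-fold lower number from compound 1 to compound 3 (0.57 log units; beyond the scatter) in the same direction. These two outcomes do not separate, given a 1.7-fold higher number from compound 2 to compound 3 (0.22 log units; within the scatter) between them. Compound 3 is the nearer guide, as its entering group also has a hydroxy at the 2 position of the name. For the measured compounds named here, no measured compound carries a diethylamino group, so the range stays wide.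

A modest move to a lower number is therefore expected in this assay and the estimated step is a 4.2-fold lower number from compound 1 to compound 4 (0.63 log units; beyond the scatter) as a working figure. Compound 4 is estimated at 4000 nM with an expected range of 1500 nM to 11000 nM for now.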

Compound 4, half-maximal inhibitory concentration: 15700 nM
The estimate for compound 4 lay 3.9-fold (0.59 log units) below the measured number, outside the stated range (above it).
By their numbers in this assay, from the lowest: compounds 2 and 3 (each within the scatter of the next); then compounds 4 and 1 (each within the scatter of the next).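

On a carbon with a double bond to nitrogen, a phenyl bearing a hydroxy group does not by itself set a compound apart from compound 1 in this assay: the step reads a 1.1-fold lower number from compound 1 to compound 4 (0.03 log units; within the scatter) and so gives no clear change, although compounds 2 and 3 each moved to a lower number. The hydroxy shared by compounds 2, 3 and 4 therefore does not settle the outcome here, since diethylamino in place of hydroxy on an aromatic carbon gives a 3.5-fold higher number from compound 3 to compound 4 (0.54 log units; beyond the scatter) and 4-(diethylamino)-2-hydroxyphenyl in place of 3,5-dibromo-4-hydroxyphenyl gives a 5.7-fold higher number from compound 2 to compound 4 (0.76 log units; beyond the scatter) as the larger of the two separations. No supporting measurement bears on the reason for this result.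

The compounds shown leave open whether dimethylamino or morpholine in place of the diethylamino would give a number nearer that of compound 3 or nearer that of compound 4. Also open, as far as these compounds go, is whether a 2-hydroxyphenyl with no further group would stand with compound 3 or with compound 1 in this assay.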